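Notes on a second fluoro in the series

The source may hold more compounds than are shown below. What is called first, only, known or untested is meant among the compounds shown, and "the series" means these compounds.

Of the compounds shown here, two on a shared core have been read so far in a functional assay on HCT-116 cells (Homo sapiens) for cytotoxicity, read by MTT assay; a lower number here means a stronger inhibitor, a higher number a weaker inhibitor. Compound 1 `Cc1cc(O)c(C(=O)/C=C/c2cccs2)c(=O)o1` gives > 100000 nM, and this is a limit of the assay, not a number. Within the data shown here, compound 2 `Cc1cc(O)c(C(=O)/C=C/c2cccc(F)c2)c(=O)o1` gives 81200 nM, the only actual number in the set.

Compound 3 `Cc1cc(O)c(C(=O)/C=C/c2ccc(F)c(F)c2)c(=O)o1` differs from compound 2 by one change fluoro in place of hydrogen on an aromatic carbon, ortho to a fluoro group and para to a large group. Among the measured compounds shown here, no measured pair shows what such a change does in this assay, so only a small shift towards a stronger value is expected, possibly none beyond the scatter. The expected size is the estimated step of a 1.4-fold lower number from compound 2 to compound 3 (0.13 log units; within the scatter). For compound 3 the estimated value is 60000 nM, with an expected range of 25000 nM to 100000 nM.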

Compound 3, half-maximal inhibitory concentration: 74900 nM
Beside the measured number, compound 3's estimate is 1.2-fold (0.10 log units) below it, within the range that was stated.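

In this assay, among these compounds, the first pair that can be read is a step of a 1.1-fold lower number from compound 2 to compound 3 (0.04 log units; within the scatter) and it lies within the scatter. Fluoro in place of hydrogen on an aromatic carbon, ortho to a fluoro group and para to a large group, therefore gives no readable change, and compound 2 and compound 3 count as equal here. Both numbers also lie not far from the limit of this assay, which leaves little room to read a further loss on this side: the limit of > 100000 nM in this assay, at which 1 of the 3 values shown sits.

Going by these compounds, whether an amine, a methoxy group or a carboxylic acid at this position would read differently stays open. Among the compounds shown here, compound 1 gives > 100000 nM, a limit of the assay and not a number, so no step to it can be read.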